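The compounds below may be only part of what the source reports. "The series", "measured", "known", "first", "only" and "open" are said of these compounds alone.

Compound 1 `Cc1ccc(CS/C(=C/c2cc(Cl)cc(Cl)c2)C(=O)c2ccc(Cl)cc2)cc1`: 10000 nM
Compound 2 `Cc1ccc(CS/C(=C/c2sccc2C)C(=O)c2ccc(Cl)cc2)cc1`: 10000 nM
Compound 3 `Cc1ccc(CS/C(=C/c2ccc(F)c(C)c2)C(=O)c2ccc(Cl)cc2)cc1`: 25000 nM

These three compounds share one core and differ only in the group on a double-bonded chain carbon bound to a double-bonded chain carbon. In a functional assay on DU-145 cells (Homo sapiens) for inhibition, read by trypan blue exclusion, with a stated time of 96 h (a lower number here means a stronger inhibitor of growth, a higher number a weaker inhibitor of growth), compound 3 gives the highest number of the three: a 2.5-fold higher number from compound 1 to compound 3 (0.40 log units; beyond the scatter) and a 2.5-fold higher number from compound 2 to compound 3 (0.40 log units; beyond the scatter), while compound 1 and compound 2 show no change at the digits printed from compound 1 to compound 2 (within the scatter). Compound 4 `Cc1ccc(CS/C(=C/c2c[nH]c3ccc(Br)cc23)C(=O)c2ccc(Cl)cc2)cc1` is not yet measured; it differs from compound 3 as follows: 5-bromo-1H-indol-3-yl in place of 4-fluoro-3-methylphenyl on a double-bonded chain carbon bound to a double-bonded chain carbon. The two steps ending at compound 3 changed the same position and were modest, so a modest step is expected here too, most likely downward because compound 3 stands at 25000 nM, the top of the range. Compound 4 is expected to give 12000 nM, between 4000 nM and 40000 nM. That estimate means an expected step of a 2.1-fold lower number from compound 3 to compound 4 (0.32 log units; beyond the scatter).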

Compound 4, concentration for 50% growth inhibition: 1000 nM
For compound 4 the middle estimate is 12-fold (1.08 log units) above the measured one, outside the stated range (below it).
By their numbers in this assay, from the lowest: compound 4; then compounds 1 and 2 (each within the scatter of the next); then compound 3.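

In this assay this position proves far more responsive than the earlier swaps suggested: 5-bromo-1H-indol-3-yl gives a 25-fold lower number from compound 3 to compound 4 (1.40 log units; beyond the scatter) and a 10-fold lower number from compound 2 to compound 4 (1.00 log units; beyond the scatter) as well as a 10-fold lower number from compound 1 to compound 4 (1.00 log units; beyond the scatter) among the compounds shown. Only compound 4 has two aromatic rings and a hydrogen-bond donor in this group, but these arrive together with the bromine, so the data cannot separate their contributions. No evidence here explains the gain. Still open, as far as these compounds go, is which feature matters, which a plain 1H-indol-3-yl without bromine or a methyl on the indole nitrogen could help separate.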